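Moving a ring nitrogen in a topoisomerase inhibitor series

A few compounds are considered here, and "the series" means these few. Any claim that something is new, unique, unknown or untested is made for them only; others in the source may bear on it.

Among the measured compounds shown here, compound 1 `Oc1ccc(-c2cc(-c3ccc(Cl)cc3)nc(-c3cccnc3)c2)cc1` is one of two compounds tested so far in an assay on isolated protein for inhibition of DNA topoisomerase 1 (Homo sapiens), with a stated time of 30 min, tested at 100 uM (a higher number here means a stronger effect of the compound at the concentration tested, a lower number a weaker effect), where compound 1 gives 18.8%. Its nearest neighbour, compound 2 `Oc1ccc(-c2cc(-c3cccnc3)nc(-c3cccc(Cl)c3)c2)cc1`, gives 55.2% in this assay, so compound 1 stands as the lower of the two numbers. For the measured compounds named here, the only step measured so far, a number 36.4 percentage points higher from compound 1 to compound 2 (beyond the scatter), concerns a different part of the molecule: the chlorophenyl ring, not the pyridine ring.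

Compound 3 `Oc1ccc(-c2cc(-c3ccncc3)nc(-c3ccc(Cl)cc3)c2)cc1` has not yet been measured. It differs from compound 1 by pyridin-4-yl in place of pyridin-3-yl on an aromatic carbon; the chlorophenyl ring is unchanged. Going by the values given here, no measured step touches the pyridine ring, so the one step on record does not speak to this change, and the safest expectation is a step of no size beyond the scatter. The estimate for compound 3 in this assay is therefore 25%, with a range from 5% to 50%. This expected change, a number 6.2 percentage points higher from compound 1 to compound 3 (within the scatter), is small, and the wide range reflects how little the two measured compounds can say about it.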

Compound 3, a percentage reported as inhibition, at one concentration (the size of the read-out at that concentration, not a potency): 5.9%
Compound 3: the middle estimate sits 19.1 percentage points above what was measured; low and high end bracket the measured number.
By their numbers in this assay, from the lowest: compound 3; then compound 1; then compound 2.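

In this assay the place on the core that carries the pyridine ring proves sensitive to where the ring nitrogen sits: with pyridin-4-yl in place of pyridin-3-yl, the read-out shows a number 12.9 percentage points lower from compound 1 to compound 3 (beyond the scatter) and this modest step comes from a swap that keeps the same atoms and the same counts of donors and acceptors in the group. Among the compounds shown here, until now the only recorded change lay in the chlorophenyl ring, where 3-chlorophenyl in place of 4-chlorophenyl gave a number 36.4 percentage points higher from compound 1 to compound 2 (beyond the scatter) and that step was large, so the read-out now responds to changes on both of these rings. No measurement at hand accounts for the drop seen with this nitrogen shift.

The compounds shown leave open whether a ring nitrogen is needed here at all, which a plain phenyl ring or a pyridin-2-yl group at the same carbon could test. They also leave open whether pyridin-4-yl would lower the number to a similar extent when paired with the 3-chlorophenyl group of compound 2.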